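The source may report more compounds than this note shows. Statements on the series, on what has been measured and on what is new or still open speak of the compounds shown alone.

Measured so far in an ADME assay on Huh-7 cells (Homo sapiens) for cytotoxicity; a higher number here means that more compound is tolerated, a lower number that less compound is tolerated:
- compound 1, `CN1CCN(CCCNCc2cn(-c3ccc(C(F)(F)F)cc3)nc2-c2ccc(OC(F)(F)F)cc2)CC1`: 2300 nM
- compound 2, `Cc1ccccc1-c1nn(-c2ccc(Br)cc2)cc1CNCCN1CCN(C)CC1`: 9600 nM
- compound 3, `CCCN1CCC(CNCc2cn(-c3ccc([N+](=O)[O-])cc3)nc2-c2ccc(Cl)cc2)CC1`: 11000 nM

Compound 2 stands second highest of the three numbers in this assay. Its nearest neighbour is compound 3, whose value lies within the usual scatter of compound 2, so the two cannot be ordered. Compound 1 gives a lower number than compound 2, and that gap lies beyond the scatter, so less of compound 1 is tolerated by the cells than of compound 2. For the measured compounds named here, no pair among the three differs in only one place, so no single structural step has yet been tied to a measured change in this assay.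

Compound 4, `Cc1ccccc1-c1nn(Cc2ccccc2)cc1CNCCN1CCN(C)CC1`, is the next compound to be run in this assay. Relative to compound 2 it shows the change (benzyl in place of 4-bromophenyl on an aromatic nitrogen). Nothing measured here speaks to a change of this kind, and the rest of the molecule is unchanged. The expectation for the step from compound 2 to compound 4 in this assay is therefore no movement beyond the scatter, in either direction; this is the estimate behind a 1.0-fold higher number from compound 2 to compound 4 (0.02 log units; within the scatter). Compound 4 is accordingly estimated at 10000 nM in this assay, with a likely range from 4000 nM to 25000 nM.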

Compound 4, half-maximal cytotoxic concentration: > 20000 nM
Compound 4 ended at the assay's limit; the forecaster's own chance of this, stated with the estimate: 15%; middle value at least 2.0-fold (0.30 log units) away from the limit.
By their numbers in this assay, from the lowest: compound 1; then compounds 2 and 3 (each within the scatter of the next). At a limit, above all of these: compound 4.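

In this assay, compound 4 gives > 20000 nM, which is a limit of the assay and not a number. For the compounds shown here, the change of benzyl in place of 4-bromophenyl on an aromatic nitrogen gives an at least 2.0-fold higher number from compound 2 to compound 4 (0.31 log units; beyond the scatter), the first single-place change tied to a shift beyond the scatter, and it shows that this position is not neutral for how much compound the cells tolerate: the two groups match in heavy-atom count and in their single six-membered aromatic ring of carbon only, yet the tolerated concentration moves upward. The step has a lower bound only, and its full size cannot be read from this pair: the limit of > 20000 nM in this assay, at which 1 of the 4 values shown sits.

The compounds shown leave open whether the shift follows the loss of bromine or the extra carbon linking the aromatic ring to the nitrogen, a question that unsubstituted phenyl or 4-bromobenzyl at this position would separate. Also open, on these data alone, is whether the same change holds with the other amine side chains of compound 1 and compound 3, or with a polar substituent such as a carboxylic acid on the benzyl ring.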